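A few compounds are considered here, and "the series" means these few. Any claim that something is new, unique, unknown or untested is made for them only; others in the source may bear on it.

In a physicochemical assay for lipophilicity, at pH 7.4 (on this read-out lower numbers stand for lower lipophilicity and higher numbers for higher lipophilicity), compound 1 (`COc1cc2c(cc1OC)CN(c1ccc(C=O)cc1)CC2`) gives 3.7 and compound 2 (`COc1cc2c(cc1OC)CN(c1ccccn1)CC2`) gives 3.7 at the digits shown, which leaves compound 2 level with compound 1 within the scatter. Compound 3 (`COc1cc2c(cc1OC)CN(c1ccc(F)cc1)CC2`) carries 4-fluorophenyl in place of pyridin-2-yl on an amine nitrogen in a ring. Among the measured compounds shown here, with compound 2 at 3.7 and no measured pair to size this change, a rise beyond the scatter in this assay is expected. On the structural change alone, the estimated step is a number 0.60 log units higher from compound 2 to compound 3 (beyond the scatter) in size. For compound 3 the estimated value is 4.3 with 3.9 to 4.8 as the expected range.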

Compound 3, distribution coefficient: 4.5
Beside the measured number, compound 3's estimate is 0.20 log units below it; the range from low to high includes it.
By their numbers in this assay, from the lowest: compounds 1 and 2 (each within the scatter of the next); then compound 3.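

In this assay, the group on the amine nitrogen in a ring now proves able to shift the read-out: 4-fluorophenyl in place of pyridin-2-yl gives a number 0.80 log units higher from compound 2 to compound 3 (beyond the scatter), and fluoro in place of formyl on an aromatic carbon gives a number 0.80 log units higher from compound 1 to compound 3 (beyond the scatter). The two changes, one replacing the whole aromatic ring and one only the group it carries, give steps of the same size. Nothing at hand accounts for these steps. Plain phenyl on that nitrogen would show how the step divides between fluoro and the ring itself. As far as these compounds go, how an amine or a carboxylic acid on the same aromatic carbon would compare with fluoro and formyl remains open.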